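Moving from a methylphenyl to a nitrophenyl amide

The compounds below may be only part of what the source reports. "The series", "measured", "known", "first", "only" and "open" are said of these compounds alone.

Measured so far:
compound 1, `Cc1ccccc1C(=O)Nc1sc2c(c1C(N)=O)CCN(C(=S)Nc1ccccc1Cl)C2`: 11000 nM
compound 2, `Cc1ccc(C(=O)Nc2sc3c(c2C(N)=O)CCN(C(=S)Nc2ccccc2Cl)C3)cc1`: 11300 nM

In a functional assay on MKN-74 cells (Homo sapiens) for antiproliferative activity, with a stated time of 24 h (a higher number here means a weaker inhibitor, a lower number a stronger inhibitor), compound 2 gives 11300 nM, and compound 1 gives 11000 nM; these two numbers lie within the usual scatter of each other, so neither can be called the stronger. For the measured compounds named here, the only measured step, a 1.0-fold higher number from compound 1 to compound 2 (0.01 log units; within the scatter), shows that moving a methyl group around the ring on the carbonyl carbon left the read-out unchanged.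

Compound 3, `NC(=O)c1c(NC(=O)c2cccc([N+](=O)[O-])c2)sc2c1CCN(C(=S)Nc1ccccc1Cl)C2`, carries a different change at the same position: 3-nitrophenyl in place of 4-methylphenyl on a carbonyl carbon. Going by the values given here, no measured step exchanges a methyl for a nitro group, so the sole guidance is that this position tolerated a change without shifting the number. The step of a 1.0-fold lower number from compound 2 to compound 3 (0.01 log units; within the scatter) is therefore expected to stay within the scatter, with a wide range to reflect the missing precedent. Compound 3 is estimated at 11000 nM, between 4000 nM and 30000 nM.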

Compound 3, half-maximal inhibitory concentration: 8850 nM
The estimate for compound 3 lay 1.2-fold (0.09 log units) above the measured number; low and high end bracket the measured number.
By their numbers in this assay, from the lowest: compounds 3, 1 and 2 (each within the scatter of the next).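

The step of a 1.3-fold lower number from compound 2 to compound 3 (0.11 log units; within the scatter) and the step of a 1.2-fold lower number from compound 1 to compound 3 (0.09 log units; within the scatter) both come from placing 3-nitrophenyl on the carbonyl carbon in this assay where a methylphenyl stood. This position therefore takes more than a moved methyl: a group that brings in nitrogen, oxygen and hydrogen-bond acceptors also leaves the number without a change that can be read. No measurement at hand explains why the read-out holds steady here.

On these data alone, all three compounds carry a six-membered aromatic ring at this place, so it remains open whether the number would hold with an amine or a carboxylic acid on that ring, or with a longer chain replacing it. As far as these compounds go, whether any group here can move the number beyond the scatter also stays open.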